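Amide-nitrogen swap and the expected cellular tolerance

A few compounds are considered here, and "the series" means these few. Any claim that something is new, unique, unknown or untested is made for them only; others in the source may bear on it.

Of the compounds shown here, three built on one shared core have been tested in an ADME assay on HepG2 2.2.15 cells (Homo sapiens) for cytotoxicity, read by MTT assay, with stated times of 48 h and 9 days; a lower number here means that less compound is tolerated, a higher number that more compound is tolerated. Compound 1 `COc1ccc(CNC(=O)/C=C/c2coc3cc(O)ccc3c2=O)cc1` gives 718000 nM. Compound 2 `COc1ccc2c(=O)c(/C=C/C(=O)NCc3ccccc3)coc2c1` gives 376000 nM. Compound 3 `COc1ccc(NC(=O)/C=C/c2coc3cc(OC)ccc3c2=O)cc1` gives 718000 nM. On these numbers compound 3 stands level with compound 1 at the digits shown, the two together at the top of the three values, and its distance from compound 2 is small enough to fall within the usual scatter.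

Compound 4 `COc1ccc(CNC(=O)/C=C/c2coc3cc(OC)ccc3c2=O)cc1` has not yet been measured in this assay. It differs from compound 3 in one place: 4-methoxybenzyl in place of 4-methoxyphenyl on an amide-type nitrogen. Going by the values given here, the one measured step that bears on this exchange is the opposite kind of swap on the same nitrogen, a 1.9-fold higher number from compound 2 to compound 3 (0.28 log units; within the scatter), which stayed within the scatter. Compound 1 also carries the 4-methoxybenzyl group and sits level with compound 3, so nothing in the data points to a shift beyond the scatter. The expected step from compound 3 to compound 4 is therefore a 1.2-fold lower number from compound 3 to compound 4 (0.06 log units; within the scatter), essentially no change. Compound 4 is estimated to give 620000 nM in this assay, with a range from 320000 nM to 1200000 nM, because compound 1 gives 718000 nM with the same group in place.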

Compound 4, half-maximal cytotoxic concentration: 43000 nM
Estimate against measurement, compound 4: 14-fold (1.16 log units) above; measured number below the stated range.
By their numbers in this assay, from the lowest: compound 4; then compounds 2, 1 and 3 (each within the scatter of the next).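

In this assay, the group on the amide-type nitrogen turns out to matter a great deal: a 17-fold lower number from compound 3 to compound 4 (1.22 log units; beyond the scatter) comes from 4-methoxybenzyl in place of 4-methoxyphenyl, whereas the earlier step on this nitrogen, a 1.9-fold higher number from compound 2 to compound 3 (0.28 log units; within the scatter), stayed within the scatter. The other two neighbours show that neither methoxy-related change can be read alone: an 8.7-fold lower number from compound 2 to compound 4 (0.94 log units; beyond the scatter) comes from methoxy in place of hydrogen on an aromatic carbon, and a 17-fold lower number from compound 1 to compound 4 (1.22 log units; beyond the scatter) comes from methyl in place of hydrogen on an oxygen on an aromatic ring, so among these four compounds the low number appears only with this particular combination of groups. No measurement available here explains why this combination is less well tolerated.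

Still open, from the compounds shown here alone, is whether a longer chain on the amide-type nitrogen, such as 2-phenylethyl, would keep the number low. The same applies to a chlorine or a dimethylamino group in place of the methoxy of the 4-methoxybenzyl group, and to an ethyl in place of the methyl on the oxygen on the aromatic ring.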